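Methoxy for acetamido: expected cytotoxicity of compound 4

The source may report more compounds than this note shows. Statements on the series, on what has been measured and on what is new or still open speak of the compounds shown alone.

Three compounds of the series have so far been run in an ADME assay on HEK293 cells (Homo sapiens) for cytotoxicity, read by CellTiter-Glo and resazurin assay, with a stated time of 72 h; on this read-out lower numbers stand for an effect already at smaller amounts and higher numbers for an effect only at larger amounts of compound. Compound 1 `CC(C)N(Cc1cccc(OCCCCCC(=O)O)c1)C(=O)c1ccc(-c2cccc3ccccc23)cc1` returns only a limit of the assay, > 26000 nM. Compound 2 `CC(=O)Nc1cccc(-c2ccc(C(=O)N(Cc3cccc(OCCCCCC(=O)O)c3)C(C)C)cc2)c1` likewise returns a limit, > 26000 nM. Compound 3 `CCOC(=O)CCCCCOc1cccc(CN(C(=O)c2ccc(-c3cccc(NC(C)=O)c3)cc2)C(C)C)c1` also stands at a limit, > 26000 nM. All three values thus sit at the limit of > 26000 nM in this assay, at which 3 of the 3 values shown sit, and neither measured step is readable: the change from compound 1 to compound 2 gives a step that the two limits leave unreadable from compound 1 to compound 2, and the change from compound 2 to compound 3 gives a step that the two limits leave unreadable from compound 2 to compound 3.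

Compound 4 `CCOC(=O)CCCCCOc1cccc(CN(C(=O)c2ccc(-c3cccc(OC)c3)cc2)C(C)C)c1` is the next to be measured in this assay. It differs from compound 3 by methoxy in place of acetamido on an aromatic carbon. Both measured steps bear on this change in one way only: one also exchanges a group on an aromatic carbon, the other alters the chain end, and in both cases the limit was not left. Among the compounds with values here, no measured step shows a size, so nothing beyond the scatter is expected from compound 3 to compound 4, and the step is estimated as a step that the limit leaves unreadable from compound 3 to compound 4. Compound 4 is expected to remain at the assay limit; its estimate in this assay is 30000 nM, with a range from 15000 nM to 60000 nM.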

Compound 4, half-maximal effective concentration: > 21000 nM
Compound 4 ended at the assay's limit; the forecaster's own chance of this, stated with the estimate: 85%; the middle value does not contradict the limit.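

Compound 3 returns only a limit in this assay, > 26000 nM. Compound 4 also returns only a limit, > 21000 nM, so no step can be read between these two compounds. The compounds shown leave open where any member of the series would give a numerical half-maximal effective concentration, and how large the effect of any group exchange would be.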